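The source may report more compounds than this note shows. Statements on the series, on what has been measured and on what is new or still open speak of the compounds shown alone.

Within the data shown here, compound 2 `COc1cc(/C=C/C2CC(=O)C=CO2)cc(OC)c1OC` is one of three compounds measured in a functional assay on NCI/ADR cells (Homo sapiens) for inhibition, read by sulforhodamine B assay, with a stated time of 48 h (a higher number here means a weaker inhibitor of growth, a lower number a stronger inhibitor of growth), where compound 2 gives 223 uM, the highest number of the three. Compound 1 `COc1ccc(/C=C/C2CC(=O)C=CO2)cc1OC` gives 146 uM in this assay. The step of a 1.5-fold higher number from compound 1 to compound 2 (0.18 log units; within the scatter) stays within the scatter. Compound 3 `O=C1C=CCC(/C=C/c2ccccc2C(F)(F)F)O1` gives 75.5 uM, a lower number than that of compound 2, and that gap lies beyond the scatter.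

Compound 4 `COc1cc(/C=C/C2CC=CC(=O)O2)cc(OC)c1OC` has not yet been measured. It differs from compound 2 by a group of 7 heavy atoms (5 carbon, 2 oxygen; one six-membered non-aromatic ring with 1 hetero atom) in place of a group of 7 heavy atoms (5 carbon, 2 oxygen; one six-membered non-aromatic ring with 1 hetero atom), on a double-bonded chain carbon bound to a double-bonded chain carbon. Among the measured compounds shown here, no measured step bears on an exchange of this kind: the only step at hand concerns a methoxy group on an aromatic carbon and was within the scatter, so it offers no guide to swapping one ring group for another of the same atoms joined differently. With nothing pointing in either direction, the analyst expects a step of a 1.1-fold lower number from compound 2 to compound 4 (0.05 log units; within the scatter), not beyond the scatter. The analyst therefore estimates compound 4 at 200 uM, with a range from 60 uM to 600 uM.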

Compound 4, concentration for growth inhibition (reported as GI): 35.1 uM
Compound 4: the middle estimate sits 5.7-fold (0.76 log units) above what was measured; measured number below the stated range.
By their numbers in this assay, from the lowest: compound 4; then compounds 3, 1 and 2 (each within the scatter of the next, the first and the last beyond it).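

In this assay, the exchange of one ring group for another with the same atoms joined differently, on a double-bonded chain carbon bound to a double-bonded chain carbon, gives a 6.4-fold lower number from compound 2 to compound 4 (0.80 log units; beyond the scatter), a step beyond the scatter. Among these compounds, this place therefore responds to how the ring group is joined, even though the two groups match in every count printed for them, whereas the only earlier step, methoxy in place of hydrogen on an aromatic carbon, stayed within the scatter. Nothing at hand accounts for the size or direction of this step.

On these data alone, whether the same exchange gives a similar step on the aromatic ring of compound 1 or compound 3 remains open. Also open, as far as these compounds go, is how an amine or a carboxylic acid on the ring group would read in this assay.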